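Swapping the triazole substituent: an aryl group replaces an amide arm

The compounds below may be only part of what the source reports. "The series", "measured", "known", "first", "only" and "open" are said of these compounds alone.

Measured so far:
Compound 1, `CCOC(=O)C1=Cc2ccccc2OC1(OCc1cn(CC(=O)Nc2ccc(OC)cc2)nn1)C(F)(F)F`: 28100 nM
Compound 2, `CCOC(=O)C1=Cc2ccccc2OC1(OCc1cn(-c2ccc(F)c([N+](=O)[O-])c2)nn1)C(F)(F)F`: 16200 nM
Compound 3, `CCOC(=O)C1=Cc2ccccc2OC1(OCc1cn(CC(=O)Nc2ccc(I)cc2Cl)nn1)C(F)(F)F`: 28100 nM

All three compounds share the same core, a fused bicyclic ether carrying an ethyl ester and a trifluoromethyl group, with a triazole attached through a methylene-oxygen link. They differ only in what sits on the triazole nitrogen. In a functional assay on MCF7 cells (Homo sapiens) for inhibition, read by MTT assay, with a stated time of 24 h (a higher number here means a weaker inhibitor, a lower number a stronger inhibitor), compound 3 gives 28100 nM, the same number as compound 1, and the remaining step is a 1.7-fold higher number from compound 2 to compound 3 (0.24 log units; within the scatter), so the three measured compounds sit together within the scatter.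

Compound 4, `CCOC(=O)C1=Cc2ccccc2OC1(OCc1cn(-c2cccc(C(F)(F)F)c2)nn1)C(F)(F)F`, has not yet been measured. The change from compound 3 is 3-(trifluoromethyl)phenyl in place of ((2-chloro-4-iodophenyl)carbamoyl)methyl on an aromatic nitrogen. Among the compounds with values here, two measured steps bear on this kind of change, where an amide arm is exchanged for a directly attached aromatic ring: a 1.7-fold lower number from compound 1 to compound 2 (0.24 log units; within the scatter) and a 1.7-fold higher number from compound 2 to compound 3 (0.24 log units; within the scatter). Both fall within the scatter. The step is therefore expected to be small: a 1.6-fold lower number from compound 3 to compound 4 (0.19 log units; within the scatter), perhaps leaning slightly toward a lower number, as compound 2 with its aryl group gave 16200 nM. Compound 4 is estimated to give 18000 nM, with a range from 8000 nM to 40000 nM.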

Compound 4, half-maximal inhibitory concentration: > 150000 nM
Compound 4: no number, only a limit (the forecaster's own chance of this, stated with the estimate: 10%); at least 8.3-fold (0.92 log units) between middle value and limit.
By their numbers in this assay, from the lowest: compounds 2, 1 and 3 (each within the scatter of the next). At a limit, above all of these: compound 4.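

In this assay compound 4 gives > 150000 nM, which is a limit of the assay and not a number. Until now, every change on this aromatic nitrogen had stayed within the scatter, but exchanging an amide arm for 3-(trifluoromethyl)phenyl gives a step beyond it, seen both as an at least 5.3-fold higher number from compound 3 to compound 4 (0.72 log units; beyond the scatter) and as an at least 5.3-fold higher number from compound 1 to compound 4 (0.72 log units; beyond the scatter). Compound 2 goes against any reading that simply losing the amide arm is what matters, since it too has an aromatic ring directly on this nitrogen, and the exchange of one such ring for another gives an at least 9.2-fold higher number from compound 2 to compound 4 (0.96 log units; beyond the scatter), so the substituents carried by a directly attached ring can matter as much as the arm itself.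

With only two directly attached rings shown, it remains open whether the trifluoromethyl group itself, its place on the ring, or the absence of the fluoro and nitro groups of compound 2 goes with this step. Going by these compounds, it also remains open how this assay would read with an unsubstituted phenyl, a benzyl, or a phenyl carrying an amine or a carboxylic acid on this nitrogen.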